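A few compounds are considered here, and "the series" means these few. Any claim that something is new, unique, unknown or untested is made for them only; others in the source may bear on it.

Working notes on the series. Compound 1 `Oc1ccc(-c2cc(-c3cccs3)cc(-c3cccc(O)c3)n2)cc1` gives 780 nM in a functional assay on T47D cells (Homo sapiens) for cytotoxicity, read by CCK-8 assay; on this read-out lower numbers stand for stronger inhibition and higher numbers for weaker inhibition. Going by the values given here, compound 2 `Oc1ccc(-c2cc(-c3cccs3)cc(-c3ccc(O)cc3)n2)cc1` gives 11700 nM, the highest of the two numbers so far; its nearest neighbour is compound 1, and the step of a 15-fold higher number from compound 1 to compound 2 (1.18 log units; beyond the scatter) is the only measured step in the set.

Compound 3 `Oc1ccc(-c2cc(-c3ccsc3)cc(-c3ccc(O)cc3)n2)cc1` is not yet measured. The change from compound 2 to compound 3 is thiophen-3-yl in place of thiophen-2-yl on an aromatic carbon; the two have the same atoms, joined differently, and the hydroxyphenyl groups of compound 2 are kept. Among the compounds with values here, no measured step touches the thiophene, so the single step from compound 1 to compound 2 does not bear on this change, and there is no basis for expecting a shift beyond the scatter in this assay in either direction. The expectation is therefore a step of no change at the digits printed from compound 2 to compound 3 (within the scatter), giving an estimate for compound 3 of 11700 nM, within the range 4000 nM to 35000 nM.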

Compound 3, half-maximal inhibitory concentration: 1770 nM
The estimate for compound 3 lay 6.6-fold (0.82 log units) above the measured number, outside the stated range (below it).
By their numbers in this assay, from the lowest: compound 1; then compound 3; then compound 2.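

Swapping thiophen-2-yl for thiophen-3-yl on the aromatic carbon opposite the ring nitrogen gives a 6.6-fold lower number from compound 2 to compound 3 (0.82 log units; beyond the scatter) in this assay, so the point of attachment of the thiophene matters here, even though the two groups have the same atoms and the two 4-hydroxyphenyl groups are kept. The earlier step, a 15-fold higher number from compound 1 to compound 2 (1.18 log units; beyond the scatter), concerned only a hydroxyphenyl group; this position is now a second place in the series where a change of attachment alone moves the number beyond the scatter. Nothing available explains the shift.

The compounds shown leave open whether thiophen-3-yl gives a similar step alongside the 3-hydroxyphenyl group of compound 1. They also leave open how an amine or a carboxylic acid at this position would read out in this assay.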